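The source may report more compounds than this note shows. Statements on the series, on what has been measured and on what is new or still open speak of the compounds shown alone.

Compound 1, `CCOC(=O)C1=Cc2ccccc2OC1(OCc1cn(-c2ccc(F)cc2)nn1)C(F)(F)F`, gives 8400 nM in a functional assay on HeLa cells (Homo sapiens) for inhibition, read by MTT assay, with a stated time of 24 h; on this read-out lower numbers stand for stronger inhibition and higher numbers for weaker inhibition. Compound 3, `CCOC(=O)C1=Cc2ccccc2OC1(OCc1cn(-c2ccc(F)c([N+](=O)[O-])c2)nn1)C(F)(F)F`, gives 15600 nM in this assay. Compound 2, `CCOC(=O)C1=Cc2ccccc2OC1(OCc1cc(-c2ccc3ccccc3c2)no1)C(F)(F)F`, gives only a limit of the assay in this assay, namely > 150000 nM.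

Compound 2 therefore stands at the limit of > 150000 nM in this assay, at which 1 of the 3 values shown sits, so its true number is not known. Compound 4, `CCOC(=O)C1=Cc2ccccc2OC1(OCc1cc(-c2ccc(F)cc2F)no1)C(F)(F)F`, is not yet measured; it differs from compound 2 by 2,4-difluorophenyl in place of naphthalen-2-yl on an aromatic carbon. Among the compounds with values here, the only measured step, a 1.9-fold higher number from compound 1 to compound 3 (0.27 log units; within the scatter), concerns another exchange on another compound pair, so it offers no guide to this one. Within the data shown here, compound 1 shows that a fluorine-bearing aromatic ring on the shared core can give a number rather than a limit, but no measured step connects it to compound 4. Compound 4 is expected at 50000 nM, with a range from 8000 nM to 150000 nM. That would mean an estimated step of an at least 3.0-fold lower number from compound 2 to compound 4 (0.47 log units; beyond the scatter).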

Compound 4, half-maximal inhibitory concentration: > 150000 nM
Compound 4: only a limit was reported; the forecaster's own chance of this, stated with the estimate: 45%; middle value at least 3.0-fold (0.47 log units) from the limit.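

Compound 2 and compound 4 both give only a limit of the assay, so no step between them can be read: the limit of > 150000 nM in this assay, at which 2 of the 4 values shown sit.

The compounds shown leave open whether naphthalen-2-yl or 2,4-difluorophenyl gives the lower true number in this assay.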